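The source may hold more compounds than are shown below. What is called first, only, known or untested is meant among the compounds shown, and "the series" means these compounds.

Working notes on a short series that shares one core and varies only the aryl group on the triazole-type ring nitrogen. Compound 1 `c1ccc(-n2cc(COc3ccccc3-c3nc4ccccc4s3)nn2)cc1` carries phenyl on the aromatic nitrogen; in a functional assay on COLO 205 cells (Homo sapiens) for cytotoxicity, read by MTT assay, with a stated time of 24 h (on this read-out higher numbers stand for weaker inhibition and lower numbers for stronger inhibition), compound 1 gives 16600 nM. Compound 2 `Fc1ccc(-n2cc(COc3ccccc3-c3nc4ccccc4s3)nn2)cc1Cl` carries 3-chloro-4-fluorophenyl in place of phenyl on an aromatic nitrogen; in this assay compound 2 gives 14400 nM. For the measured compounds named here, compound 2 therefore stands alongside compound 1 rather than apart from it, the only measured step being a 1.2-fold lower number from compound 1 to compound 2 (0.06 log units; within the scatter), and the two numbers do not separate the compounds.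

Compound 3 `FC(F)(F)c1cccc(-n2cc(COc3ccccc3-c3nc4ccccc4s3)nn2)c1` is the next point: 3-(trifluoromethyl)phenyl in place of 3-chloro-4-fluorophenyl on an aromatic nitrogen. Going by the values given here, the single measured step bears directly on this change, since it also swaps the aryl group on the aromatic nitrogen, and it came out as a 1.2-fold lower number from compound 1 to compound 2 (0.06 log units; within the scatter). On that basis no step beyond the scatter is expected in this assay, and the expected step is a 1.0-fold higher number from compound 2 to compound 3 (0.02 log units; within the scatter). For compound 3 in this assay the estimate is 15000 nM, with a range from 7000 nM to 32000 nM.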

Compound 3, half-maximal inhibitory concentration: 10800 nM
The estimate for compound 3 lay 1.4-fold (0.14 log units) above the measured number, and the stated range covers the measured number.
By their numbers in this assay, from the lowest: compounds 3, 2 and 1 (each within the scatter of the next).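

At the aryl group on the aromatic nitrogen of the five-membered ring, this assay gives a 1.3-fold lower number from compound 2 to compound 3 (0.12 log units; within the scatter) for 3-(trifluoromethyl)phenyl in place of 3-chloro-4-fluorophenyl, and a 1.5-fold lower number from compound 1 to compound 3 (0.19 log units; within the scatter) for trifluoromethyl in place of hydrogen on an aromatic carbon of the phenyl group. Compound 3 therefore extends the earlier result in two ways: a second substituted aryl group also stays within the scatter of phenyl, and the exchange of one substituted aryl group for another, going from 8 to 10 heavy atoms, separates neither compound. So far, phenyl, 3-chloro-4-fluorophenyl and 3-(trifluoromethyl)phenyl cannot be told apart at this position in this read-out, and no measurement here offers an account of that.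

Open, on these data alone, is whether any group at this position can move the number beyond the scatter, for example an aryl ring bearing an amine or a carboxylic acid, or a longer alkyl chain in place of the aryl ring. The compounds shown also leave open how much the rest of the shared core contributes, since all three vary in this one place only.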